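A few compounds are considered here, and "the series" means these few. Any claim that something is new, unique, unknown or untested is made for them only; others in the source may bear on it.

Compound 3 `CN1CCN(c2ccc(Nc3ncc(Cl)c(NCc4ccc(C(F)(F)F)cc4)n3)nc2)CC1` is the compound from which this step sets out. In an ADME assay on L02 cells (Homo sapiens) for inhibition, read by CCK-8 assay, with a stated time of 48 h (on this read-out lower numbers stand for stronger inhibition of growth and higher numbers for weaker inhibition of growth), compound 3 gives 26200 nM, the highest of the two numbers recorded. Its nearest neighbour on that scale is compound 2 `Cc1ccccc1Nc1nc(Nc2ccc(N3CCN(C)CC3)cc2)ncc1Cl`, which gives 6510 nM. Compound 1 `Cc1ccc(Nc2ncc(Cl)c(Nc3ccccc3C)n2)cc1` gives only a limit, > 100000 nM, which is the limit (the limit of > 100000 nM in this assay, at which 1 of the 3 values shown sits). Going by the values given here, the one step measured between two compounds that differ in a single place is an at least 15-fold lower number from compound 1 to compound 2 (1.18 log units; beyond the scatter), a change at a different position from the one now in question.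

Compound 4 `Cc1cc(C)c(Nc2nc(Nc3ccc(N4CCN(C)CC4)cn3)ncc2Cl)c(C)c1` differs from compound 3 by 2,4,6-trimethylphenyl in place of 4-(trifluoromethyl)benzyl on a nitrogen on an aromatic ring. Among the compounds with values here, no measured step touches this position, so no measured step bears directly on the change, and the values of compound 2 and compound 3 show only a gap that has no counterpart in a single-change step. The expectation for compound 4 is therefore a step from compound 3 of a 1.5-fold lower number from compound 3 to compound 4 (0.16 log units; within the scatter), within the scatter. Compound 4 is estimated at 18000 nM, between 5000 nM and 70000 nM.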

Compound 4, concentration for 50% growth inhibition: 20500 nM
Estimate against measurement, compound 4: 1.1-fold (0.06 log units) below; the range from low to high includes it.
By their numbers in this assay, from the lowest: compound 2; then compounds 4 and 3 (each within the scatter of the next). At a limit, above all of these: compound 1.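

At this position, on a nitrogen on an aromatic ring, this assay now gives its first single-change reading, a 1.3-fold lower number from compound 3 to compound 4 (0.11 log units; within the scatter). The earlier compounds shown here offered no such reading, and this one shows that, for this pair, 2,4,6-trimethylphenyl and 4-(trifluoromethyl)benzyl cannot be told apart on this read-out, although one group holds only carbon and the other also holds fluorine. Nothing on record bears on why these two groups read alike.

Both groups carry a six-membered aromatic ring of carbon only, so the compounds shown leave open how this read-out responds when that ring gives way at this nitrogen to a longer alkyl chain, an amine or a carboxylic acid. They also leave open whether the same exchange would read alike on a core carrying a different group at another position.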